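Quaternary carboxy branch on the shared core

The source may hold more compounds than are shown below. What is called first, only, known or untested is meant among the compounds shown, and "the series" means these compounds.

Compound 1 `C[C@@H](C(=O)O)c1nn(Cc2cn3cc(OCC4CC4)c(Cl)cc3n2)c2ccccc2c1=O` gives the highest number of the three measured compounds in a functional assay on HFL1 cells for antagonist activity at sphingosine 1-phosphate receptor 2 (Homo sapiens), read by ELISA, with a stated time of 24 h (on this read-out lower numbers stand for stronger inhibition and higher numbers for weaker inhibition), with compound 1 at 182 nM. Compound 2 `CCC(C(=O)O)c1nn(Cc2cn3cc(OCC4CC4)c(Cl)cc3n2)c2ccccc2c1=O` gives 5.6 nM and compound 3 `CC(C(=O)O)c1nn(Cc2cn3cc(OCC4CC4)c(C(F)(F)F)cc3n2)c2ccccc2c1=O` gives 5 nM. Compound 4 `CC(C)(C(=O)O)c1nn(Cc2cn3cc(OCC4CC4)c(Cl)cc3n2)c2ccccc2c1=O` differs from compound 1 as follows: 1-carboxy-1-methylethyl in place of 1-carboxyethyl on an aromatic carbon. Within the data shown here, the one step that bears on this change is the chain extension at the same carbon, a 33-fold lower number from compound 1 to compound 2 (1.51 log units; beyond the scatter), which suggests that a further carbon at this position can lower the number sharply. A second methyl is not a chain extension, so the outcome is less certain. Compound 4 is therefore expected to show a lower number, a 6.1-fold lower number from compound 1 to compound 4 (0.78 log units; beyond the scatter), with an estimate of 30 nM and a range from 5 nM to 200 nM.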

Compound 4, half-maximal inhibitory concentration: 21 nM
Compound 4: the middle estimate sits 1.4-fold (0.15 log units) above what was measured; the range from low to high includes it.
By their numbers in this assay, from the lowest: compounds 3 and 2 (each within the scatter of the next); then compound 4; then compound 1.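

In this assay, a second methyl on the carbon bearing the carboxy group also brings an 8.7-fold lower number from compound 1 to compound 4 (0.94 log units; beyond the scatter), so lowering the number at this position does not depend on extending the chain. The change from 1-carboxypropyl to 1-carboxy-1-methylethyl gives a 3.8-fold higher number from compound 2 to compound 4 (0.57 log units; beyond the scatter), which shows that the two added-carbon arrangements are not equivalent here. Nothing available explains either step.

The 1-carboxyethyl of compound 1 has a defined stereocentre and the group in compound 4 has none, so the mirror-image form of compound 1 remains an open comparison. On these data alone, how a 1-carboxybutyl chain or a cyclopropane ring carrying the carboxylic acid would read also remains open.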